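The compounds below may be only part of what the source reports. "The series", "measured", "known", "first", "only" and "open" are said of these compounds alone.

Measured in a functional assay on PANC-1 cells (Homo sapiens) for inhibition, read by MTT assay, with a stated time of 24 h; a lower number here means a stronger inhibitor, a higher number a weaker inhibitor:
compound 1, `CC1(C)[C@H]2CC[C@]1(C)N(Cc1cn(-c3ccccc3Br)nn1)C(=O)C2`: 280 nM
compound 2, `CC1(C)[C@H]2CC[C@]1(C)N(Cc1cn(-c3ccccc3C#N)nn1)C(=O)C2`: 240 nM
compound 3, `CC1(C)[C@H]2CC[C@]1(C)N(Cc1cn(-c3ccccc3)nn1)C(=O)C2`: 160 nM

Compound 2 stands second highest of the three numbers. The nearest number is reached by a 1.2-fold lower number from compound 1 to compound 2 (0.07 log units; within the scatter) and the furthest by a 1.5-fold lower number from compound 2 to compound 3 (0.18 log units; within the scatter); both lie within the scatter, as does a 1.8-fold lower number from compound 1 to compound 3 (0.24 log units; within the scatter). Compound 4, `CC1(C)[C@H]2CC[C@]1(C)N(Cc1cn(-c3ccccc3O)nn1)C(=O)C2`, differs from compound 2 as follows: hydroxy in place of cyano on an aromatic carbon. Within the data shown here, the steps that bear on this change are hydrogen in place of cyano on an aromatic carbon, a 1.5-fold lower number from compound 2 to compound 3 (0.18 log units; within the scatter), and cyano in place of bromo on an aromatic carbon, a 1.2-fold lower number from compound 1 to compound 2 (0.07 log units; within the scatter); neither moved the number beyond the scatter. The expectation for compound 4 is therefore no step beyond the scatter, a 1.2-fold lower number from compound 2 to compound 4 (0.08 log units; within the scatter), in this assay. Compound 4 is estimated at 200 nM, within 100 nM to 400 nM.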

Compound 4, half-maximal inhibitory concentration: 230 nM
Compound 4: the middle estimate sits 1.2-fold (0.06 log units) below what was measured, and the stated range covers the measured number.
By their numbers in this assay, from the lowest: compounds 3, 4, 2 and 1 (each within the scatter of the next).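

In this assay the exchange of cyano for hydroxy on this aromatic carbon, ortho to a large group, brings in a hydrogen-bond donor, yet the number stays within the scatter (a 1.0-fold lower number from compound 2 to compound 4 (0.02 log units; within the scatter)). The same holds for hydroxy against hydrogen (a 1.4-fold higher number from compound 3 to compound 4 (0.16 log units; within the scatter)) and against bromo (a 1.2-fold lower number from compound 1 to compound 4 (0.09 log units; within the scatter)), so this read-out separates none of the four groups shown at this position. Nothing available explains this flat result.

As far as these compounds go, whether an amine, a carboxylic acid or a longer chain at this place would give a step beyond the scatter remains open.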